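This account rests on a few compounds, and the source may have more. Where it says the series, first, only, none or still open, it means among the compounds named here.

Compound 1 `COc1ccc2nc(NC(=O)c3cn(-c4ccccc4)nc3-c3ccccc3)sc2c1` in a functional assay on A549 cells (Homo sapiens) for cytotoxicity, read by MTT assay, with a stated time of 72 h (on this read-out lower numbers stand for stronger inhibition and higher numbers for weaker inhibition), gives only a limit, > 50000 nM. Compound 2 `COc1ccc2nc(NC(=O)c3cn(-c4ccccc4)nc3-c3ccc(F)cc3)sc2c1` in this assay likewise gives only a limit, > 50000 nM. The change fluoro in place of hydrogen on an aromatic carbon therefore yields a step that the two limits leave unreadable from compound 1 to compound 2, as both values sit at the limit of > 50000 nM in this assay, at which 2 of the 3 values shown sit. For the measured compounds named here, compound 3 `COc1ccc(-c2nn(-c3ccccc3)cc2C(=O)Nc2nc3ccccc3s2)cc1` in this assay gives 13700 nM, the single number in the set; how its core differs from that of compound 1 is not broken down here. Compound 4 `COc1ccc(-c2nn(-c3ccccc3)cc2C(=O)Nc2nc3ccc(F)cc3s2)cc1` carries the same kind of change, (fluoro in place of hydrogen on an aromatic carbon), but the place differs: in compound 4 the ring is part of a fused system, meta and para to a fused ring, whereas in compound 2 it is para to a large group. With the earlier step unreadable, the expectation for compound 4 rests on compound 3 at 13700 nM, and the estimated step of a 1.0-fold higher number from compound 3 to compound 4 (0.01 log units; within the scatter) is expected to stay within scatter. Compound 4 is thus estimated at 14000 nM, between 5000 nM and 45000 nM.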

Compound 4, half-maximal inhibitory concentration: 7560 nM
Compound 4: middle estimate off by 1.9-fold (0.27 log units), on the high side; the measured number falls inside the stated range.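

In this assay, the change from 1,3-benzothiazol-2-yl to 6-fluoro-1,3-benzothiazol-2-yl gives a 1.8-fold lower number from compound 3 to compound 4 (0.26 log units; within the scatter), so on the core of compound 3 fluoro in place of hydrogen shows no effect that stands clear of the scatter. The same change on the core of compound 1 cannot be read, as compound 1 and compound 2 each give a limit and not a number: the limit of > 50000 nM in this assay, at which 2 of the 4 values shown sit. For the compounds shown here, the series therefore offers only one readable step, which shows neither that the change carries over from one core to the other nor that it does not.

Still open, on these data alone, is how an amine or a carboxylic acid at the same aromatic carbon would read out in this assay on the core of compound 3. Also open, as far as these compounds go, is whether any such replacement would give a step beyond the scatter.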